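Swapping the Aryl Group on a Sulfur-Bound Chain

The source may report more compounds than this note shows. Statements on the series, on what has been measured and on what is new or still open speak of the compounds shown alone.

Of the compounds shown here, three sharing one core have been measured in an ADME assay on GES1 cells (Homo sapiens) for inhibition, read by MTT assay, with a stated time of 72 h; on this read-out higher numbers stand for weaker inhibition and lower numbers for stronger inhibition. Compound 1 `Cc1cc(Nc2cc(-c3ccccc3)[nH]n2)n2nc(SCCc3ccccc3)nc2n1` gives 37400 nM, and compound 2 `Cc1cc(Nc2cc(-c3ccccc3)[nH]n2)n2nc(SCc3c(Cl)cccc3Cl)nc2n1` gives 39600 nM. Compound 3 `Cc1cc(Nc2cc(-c3ccccc3)[nH]n2)n2nc(SCc3cccc(Br)c3)nc2n1` gives > 50000 nM, which is a limit of the assay and not a number. It therefore stands at the limit of > 50000 nM in this assay, at which 1 of the 3 values shown sits.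

Compound 4 `Cc1cc(Nc2cc(-c3ccccc3)[nH]n2)n2nc(SCc3ccc(Cl)cc3)nc2n1` differs from compound 3 by 4-chlorophenyl in place of 3-bromophenyl on a saturated chain carbon bound to a sulfur, with 4-chlorophenyl in place of 3-bromophenyl on a saturated chain carbon bound to a sulfur. The measured steps at this same place bear directly on that change. They are a 1.1-fold higher number from compound 1 to compound 2 (0.02 log units; within the scatter), an at least 1.3-fold higher number from compound 1 to compound 3 (0.12 log units; that floor lies within the scatter) and an at least 1.2-fold higher number from compound 2 to compound 3 (0.10 log units; that floor lies within the scatter). None of them shows a change beyond the scatter, so no step beyond the scatter is expected here either. The estimated change is an at least 1.1-fold lower number from compound 3 to compound 4 (0.04 log units; that floor lies within the scatter). Compound 4 is expected at about 45000 nM, with an estimated range of 28000 nM to 70000 nM.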

Compound 4, half-maximal inhibitory concentration: 31800 nM
Compound 4: middle estimate off by 1.4-fold (0.15 log units), on the high side; measured number inside the range.
By their numbers in this assay, from the lowest: compounds 4, 1 and 2 (each within the scatter of the next). At a limit, above all of these: compound 3.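

Putting 4-chlorophenyl in place of 3-bromophenyl gives compound 4 a measured number in this assay, yet the step is only a floor, an at least 1.5-fold lower number from compound 3 to compound 4 (0.19 log units; that floor lies within the scatter). Compound 3 stays at a limit of the assay and not a number: the limit of > 50000 nM in this assay, at which 1 of the 4 values shown sits. The other two steps, a 1.2-fold lower number from compound 2 to compound 4 (0.10 log units; within the scatter) and a 1.2-fold lower number from compound 1 to compound 4 (0.07 log units; within the scatter), show that benzyl, 2,6-dichlorophenyl and 4-chlorophenyl do not separate at this place on a saturated chain carbon bound to a sulfur.

The compounds shown leave open whether any group here can move the number beyond the scatter, for instance a chain ending in an amine or a carboxylic acid in place of the aryl ring. They also leave open how far compound 3 truly lies from compound 4.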